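Swapping a Basic Amine Chain for an Azetidine Urea

The compounds below may be only part of what the source reports. "The series", "measured", "known", "first", "only" and "open" are said of these compounds alone.

Compound 1 `O=C(Nc1ccc(S(=O)(=O)N2CCCCC2)c2ccccc12)c1ccccc1` reports only a limit and no number in an assay on L1.2 cells for binding affinity to C-C chemokine receptor type 8 (Homo sapiens); on this read-out lower numbers stand for stronger inhibition and higher numbers for weaker inhibition: compound 1 gives > 30000 nM, which is the limit of > 30000 nM in this assay, at which 1 of the 3 values shown sits.
Compound 2 `CCOC(=O)N1CCC(NS(=O)(=O)c2ccc(C(=O)Nc3ccccc3C)c3ccccc23)CC1` gives 5.21 nM in this assay.
Compound 3 `Cc1ccccc1C(=O)Nc1ccc(S(=O)(=O)NC2CCN(C(=O)CCCN)CC2)c2ccccc12` gives 1.6 nM in this assay.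

Of the two compounds with a number in this assay, compound 3 has the lower one, and its distance from compound 2 lies beyond the usual scatter. Compound 4 `Cc1ccccc1C(=O)Nc1ccc(S(=O)(=O)NC2CCN(C(=O)N3CCC3)CC2)c2ccccc12` keeps the whole shared core of compound 3 and changes only the group attached to the carbonyl on the piperidine nitrogen: azetidin-1-yl in place of 3-aminopropyl on a carbonyl carbon. Compound 2 already shows that a neutral group on that same nitrogen, the ethyl carbamate, still gives strong binding with 5.21 nM, so a neutral urea in compound 4 is expected to land in the same region. The expected step from compound 3 to compound 4 is a modest weakening, a 2.8-fold higher number from compound 3 to compound 4 (0.45 log units; beyond the scatter), not far past the scatter. Compound 4 is therefore estimated at 4.5 nM, with a likely range from 1.5 nM to 15 nM.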

Compound 4, inhibition constant: 3.5 nM
Estimate against measurement, compound 4: 1.3-fold (0.11 log units) above; measured number inside the range.
By their numbers in this assay, from the lowest: compound 3; then compounds 4 and 2 (each within the scatter of the next). At a limit, above all of these: compound 1.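

In this assay, azetidin-1-yl in place of 3-aminopropyl on the carbonyl carbon gives a 2.2-fold higher number from compound 3 to compound 4 (0.34 log units; beyond the scatter), a modest step. This shows that the open chain with its amine can leave this position without a large loss: the group that enters counts no hydrogen-bond donors or acceptors, and compound 4 still gives 3.5 nM. Nothing measured here accounts for the size of this step.

The compounds shown do not separate the loss of the amine from the gain of the four-membered ring, as both change in the same step. From the compounds shown here alone, it remains open how a pyrrolidin-1-yl group, a dimethylamino group or an azetidine carrying an amine on the same carbonyl carbon would read in this assay.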